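Swapping a pyrazole for trifluoromethyl on a shared core

A few compounds are considered here, and "the series" means these few. Any claim that something is new, unique, unknown or untested is made for them only; others in the source may bear on it.

Measured so far:
Compound 1, `Cn1ccc2cc(-c3cc4nccc(-c5ccc(F)cc5)n4n3)ccc21`: 2160 nM
Compound 2, `COc1cc(-c2ccnc3cc(-c4ccc(-c5cnn(C)c5)cc4)nn23)cc(OC)c1OC`: 2110 nM
Compound 3, `COc1cc(-c2ccnc3cc(-c4cn(C(=O)OC(C)(C)C)c5ccccc45)nn23)cc(OC)c1OC`: 5720 nM

These three compounds were tested in a functional assay on HCT-116 cells (Homo sapiens) for inhibition, read by CCK-8 assay, with a stated time of 48 h; a higher number here means a weaker inhibitor, a lower number a stronger inhibitor. Compound 2 gives the lowest of the three numbers, yet compound 1 sits so close that the two cannot be told apart within the usual scatter. Compound 3 stands clearly higher, beyond the scatter, so among the measured compounds it is the weaker inhibitor. Among the measured compounds shown here, no two measured compounds differ in only one place, so no single-change step is on hand to guide the next prediction.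

The unmeasured compound 4, `COc1cc(-c2ccnc3cc(-c4ccc(C(F)(F)F)cc4)nn23)cc(OC)c1OC`, differs from compound 2 in one group on the shared core: trifluoromethyl in place of 1-methyl-1H-pyrazol-4-yl on an aromatic carbon. A small, ring-free group takes the place of a five-membered aromatic ring carrying two nitrogen atoms.

For the measured compounds named here, with no comparable step to lean on, the expectation is that the change moves the number in this assay little, if at all, beyond the scatter, with a slight tilt toward a higher number. Compound 4 is therefore estimated at 3000 nM, within a range of 1000 nM to 9000 nM, which means an expected step of a 1.4-fold higher number from compound 2 to compound 4 (0.15 log units; within the scatter).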

Compound 4, half-maximal inhibitory concentration: 1860 nM
Compound 4: middle estimate off by 1.6-fold (0.21 log units), on the high side; the range from low to high includes it.
By their numbers in this assay, from the lowest: compounds 4, 2 and 1 (each within the scatter of the next); then compound 3.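

Read in this assay, the exchange gives a 1.1-fold lower number from compound 2 to compound 4 (0.05 log units; within the scatter), so at this place on the shared core, on a six-membered aromatic ring of carbon only and para to a large group, trifluoromethyl and 1-methyl-1H-pyrazol-4-yl cannot be told apart. Among the compounds shown here, this pair is the only single-change comparison here, and it shows that losing the five-membered aromatic ring, with its two nitrogen atoms and two hydrogen-bond acceptors, leaves the number indistinguishable from that of the pyrazole compound, even though the incoming group has no ring and no hydrogen-bond acceptors. Nothing measured here gives a reason why these two different groups yield such similar numbers.

Still open, on these data alone, is whether any group at this place can move the number in this assay beyond the scatter in either direction, for example an amine, a carboxylic acid or a longer chain such as butyl. Also open, as far as these compounds go, is whether the same exchange would give a similarly small step on a different core, since this one pair cannot show how far the result extends.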